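The source may hold more compounds than are shown below. What is called first, only, known or untested is meant among the compounds shown, and "the series" means these compounds.

Measured compounds in a toxicity assay on THP-1 cells (Homo sapiens) for cytotoxicity, read by MTT assay, with a stated time of 72 h; a lower number here means that less compound is needed, a higher number that more compound is needed for the effect:
compound 1 `Cc1cccc(Cn2cc(/C=N/NC(N)=S)c3ccccc32)c1` — 32000 nM
compound 2 `CCCCn1cc(/C=N/NC(N)=S)c2cccc(C)c21` — > 200000 nM
compound 3 `COc1ccc(/C=N/NC(N)=S)c2ccccc12` — 47000 nM

In this assay compound 2 does not give a number but only a limit, (the limit of > 200000 nM in this assay, at which 1 of the 3 values shown sits). Compound 3 stands close to compound 1, and the gap between the two lies within the usual scatter, so neither can be put ahead of the other. Compound 4 `CCCCOc1ccc(/C=N/NC(N)=S)c2ccccc12` differs from compound 3 by one change: propyl in place of hydrogen on a saturated chain carbon bound to an oxygen on an aromatic ring. Within the data shown here, no measured pair shows this change, so no step can be read from the data. Compound 4 is therefore expected to stay near compound 3, with a 1.1-fold higher number from compound 3 to compound 4 (0.03 log units; within the scatter) as the estimated step. Compound 4 is estimated at 50000 nM, between 15000 nM and 200000 nM.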

Compound 4, half-maximal effective concentration: > 200000 nM
Compound 4 ended at the assay's limit; the forecaster's own chance of this, stated with the estimate: 25%; at least 4.0-fold (0.60 log units) between middle value and limit.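

Among these compounds, on the saturated chain carbon bound to an oxygen on an aromatic ring, going from methoxy to butoxy gives the first single-place step that can be read in this assay, and it lies beyond the scatter: an at least 4.2-fold higher number from compound 3 to compound 4 (0.62 log units; beyond the scatter). So this position responds to the change, which the earlier compounds could not show. The result for compound 4 is a limit and not a number: the limit of > 200000 nM in this assay, at which 2 of the 4 values shown sit.

Going by these compounds, how far the step extends past that limit stays open. So does how an ethoxy group, or a butoxy chain ending in an amine or a carboxylic acid, would read at this place.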